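This account rests on a few compounds, and the source may have more. Where it says the series, first, only, none or still open, it means among the compounds named here.

Compound 2 `CC(C)C1CC(=O)c2s/c(=N/c3ccccc3)oc2C1` stands at the low end of the three numbers in a functional assay on NUGC-3 cells (Homo sapiens) for antiproliferative activity, read by sulforhodamine B assay (on this read-out higher numbers stand for weaker inhibition of growth and lower numbers for stronger inhibition of growth), where compound 2 gives 1220 nM. Compound 1 `CC1CC(=O)c2s/c(=N/c3ccccc3)oc2C1` sits nearest and gives 1890 nM; the step of a 1.5-fold lower number from compound 1 to compound 2 (0.19 log units; within the scatter) stays within the scatter. Within the data shown here, compound 3 `CC1(C)CC(=O)c2s/c(=N/c3ccc(Cl)cc3)oc2C1` is furthest and gives 2940 nM, a gap beyond the scatter, but compound 3 differs from compound 2 in two places and yields no single-change step. Compound 4 `CC(C)C1CC(=O)c2s/c(=N/c3ccc(F)cc3)oc2C1` differs from compound 2 by fluoro in place of hydrogen on an aromatic carbon, the change sitting para to a large group. Among the measured compounds shown here, no measured step bears on a ring hydrogen being replaced; the only step on record concerns a saturated ring carbon. With nothing bearing on this change, no step beyond the scatter is expected in this assay. Compound 4 is therefore expected to give 1300 nM, within 600 nM to 2800 nM. This means an expected step of a 1.1-fold higher number from compound 2 to compound 4 (0.03 log units; within the scatter).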

Compound 4, concentration for 50% growth inhibition: 670 nM
For compound 4 the middle estimate is 1.9-fold (0.29 log units) above the measured one; measured number inside the range.
By their numbers in this assay, from the lowest: compounds 4, 2, 1 and 3 (each within the scatter of the next, the first and the last beyond it).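

In this assay, among these compounds, the change from phenyl to 4-fluorophenyl, para to a large group, gives a 1.8-fold lower number from compound 2 to compound 4 (0.26 log units; within the scatter) and is the first reading at this position. With the isopropyl group kept, fluoro in place of hydrogen on this aromatic carbon therefore leaves the number within the scatter. Nothing measured here bears on the reason for this small step.

Going by these compounds, whether an amine, a methoxy group or a carboxylic acid in the same place would give a step beyond the scatter remains open. Also open, on these data alone, is how chloro there compares with fluoro when the isopropyl group is kept.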